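From trifluoromethyl to 4-methylphenyl on a sulfonyl sulfur

The source may hold more compounds than are shown below. What is called first, only, known or untested is meant among the compounds shown, and "the series" means these compounds.

Compound 1 `C=C[C@@](C)(/C=C/c1ccc(OCc2ccccc2)cc1)CCC=C(C)C`: > 52000 nM (a limit)
Compound 2 `C=C[C@@](C)(/C=C/c1ccc(OS(=O)(=O)C(F)(F)F)cc1)CCC=C(C)C`: > 52000 nM (a limit)

In a functional assay on HepG2 cells (Homo sapiens) for cytotoxicity, with a stated time of 72 h (on this read-out higher numbers stand for an effect only at larger amounts of compound and lower numbers for an effect already at smaller amounts), compound 2 gives > 52000 nM, which is a limit and not a measured number. Compound 1 gives > 52000 nM, which is also a limit. Both compounds therefore stand at the same place: the limit of > 52000 nM in this assay, at which 2 of the 2 values shown sit.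

The next compound, compound 3 `C=C[C@@](C)(/C=C/c1ccc(OS(=O)(=O)c2ccc(C)cc2)cc1)CCC=C(C)C`, carries 4-methylphenyl in place of trifluoromethyl on a sulfonyl sulfur.

Among the measured compounds shown here, only one measured step bears on this change: a step that the two limits leave unreadable from compound 1 to compound 2. That step put (trifluoromethyl)sulfonyl in place of benzyl on an oxygen on an aromatic ring, and it offers no size to carry forward. With no readable step to build on, no change beyond the usual scatter is expected in this assay, in either direction. The expectation rests on compound 2, whose limit is > 52000 nM. The expected move is a step that the limit leaves unreadable from compound 2 to compound 3. The estimate for compound 3 is 60000 nM, with an expected range from 25000 nM to 120000 nM. The assay may well report only a limit again.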

Compound 3, half-maximal effective concentration: > 52000 nM
Compound 3: a limit, no number; the forecaster's own chance of this, stated with the estimate: 75%; the middle value is on the limit's open side.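

In this assay compound 3 gives only a limit, as compound 2 does, so no size can be read for the change from trifluoromethyl to 4-methylphenyl on the sulfonyl sulfur. What stays open is whether any of these groups changes the effect on these cells at all, with all three compounds still at one place: the limit of > 52000 nM in this assay, at which 3 of the 3 values shown sit.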